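A few compounds are considered here, and "the series" means these few. Any claim that something is new, unique, unknown or untested is made for them only; others in the source may bear on it.

In an ADME assay on A549 cells (Homo sapiens) for cytotoxicity, read by resazurin assay, with a stated time of 48 h (a higher number here means that more compound is tolerated, a lower number that less compound is tolerated), compound 1 `O=C(Nc1ccc(NCc2ccc(F)cc2)cc1Cl)c1cc(Cl)ccc1O` gives 54400 nM while compound 2 `O=C(Nc1ccc(NCc2cc(F)cc(Cl)c2)cc1Cl)c1cc(Cl)ccc1O` gives 11100 nM and compound 3 `O=C(Nc1ccc(NCc2cc(Cl)cc(Cl)c2)cc1Cl)c1cc(Cl)ccc1O` gives 13300 nM (the last two level within the scatter, a 1.2-fold higher number from compound 2 to compound 3 (0.08 log units; within the scatter)). Compound 3 thus sits with compound 2 at the lower end of these numbers. Compound 4 `O=C(Nc1ccc(NCc2cnccc2Cl)cc1Cl)c1cc(Cl)ccc1O` carries 4-chloropyridin-3-yl in place of 3,5-dichlorophenyl on a saturated chain carbon bound to a nitrogen on an aromatic ring. Two modest measured steps at this place bear on it (a 4.9-fold lower number from compound 1 to compound 2 (0.69 log units; beyond the scatter)) and (a 4.1-fold lower number from compound 1 to compound 3 (0.61 log units; beyond the scatter)). Compound 4 keeps only a chloro on this ring, and compound 1 likewise bears only a fluoro, which suggests a partial move back towards the number of compound 1. For the measured compounds named here, no measured compound has a ring nitrogen at this place, so this reading is uncertain. The expected step is modest and towards a higher number (a 2.1-fold higher number from compound 3 to compound 4 (0.32 log units; beyond the scatter)). In this assay the estimate for compound 4 is 28000 nM with an expected range of 11000 nM to 65000 nM around it.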

Compound 4, half-maximal cytotoxic concentration: 126000 nM
Estimate against measurement, compound 4: 4.5-fold (0.65 log units) below; the whole stated range lies below it.
By their numbers in this assay, from the lowest: compounds 2 and 3 (each within the scatter of the next); then compound 1; then compound 4.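

Replacing the phenyl ring with 4-chloropyridin-3-yl on a saturated chain carbon bound to a nitrogen on an aromatic ring raises the number in this assay in all three comparisons (a 9.5-fold higher number from compound 3 to compound 4 (0.98 log units; beyond the scatter)) (an 11-fold higher number from compound 2 to compound 4 (1.06 log units; beyond the scatter)) (a 2.3-fold higher number from compound 1 to compound 4 (0.36 log units; beyond the scatter)). The halogenated phenyl compounds alone left compound 1 with the highest number, whereas compound 4 shows that this place can carry a chloro-bearing ring with one hetero atom and exceed compound 1. No measurement available here accounts for this shift.

The ring nitrogen and the change in chloro pattern arrive together, so their separate contributions cannot be read from these compounds. Plain pyridin-3-yl, or 4-fluoropyridin-3-yl, at this place would help to separate them.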